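A ring nitrogen substituent swap on a chalcone scaffold

The source may hold more compounds than are shown below. What is called first, only, known or untested is meant among the compounds shown, and "the series" means these compounds.

Among the measured compounds shown here, compound 3 `O=C(/C=C/c1ccc(Cl)cc1)c1ccc(N2CCN(c3cccc(Cl)c3)CC2)cc1` gives 5.85% in a functional assay on the whole organism (strain Kunming) for inhibition, with Mus musculus as the target, with a stated time of 1 h, at a dose of 40 mg/kg by the oral route (on this read-out higher numbers stand for more inhibition at the one dose given (going by the name of the read-out) and lower numbers for less inhibition), the lowest of the three numbers measured so far. For the measured compounds named here, its closest neighbour is compound 1 `O=C(/C=C/c1ccccc1)c1ccc(N2CCN(c3cccc(Cl)c3)CC2)cc1`, which in this assay gives 14.1%; the only step between two compounds that differ in one place, a number 8.3 percentage points lower from compound 1 to compound 3 (within the scatter), is within the scatter. Compound 2 `COc1ccc(/C=C/C(=O)c2ccc(N3CCN(c4ccc(Cl)c(Cl)c4)CC3)cc2)cc1OC` stands far off with 63.5% in this assay, but it differs from compound 3 in more than one place, so its gap cannot be tied to a single change.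

Compound 4 `COc1ccccc1N1CCN(c2ccc(C(=O)/C=C/c3ccc(Cl)cc3)cc2)CC1` has not yet been measured. It arises from compound 3 by 2-methoxyphenyl in place of 3-chlorophenyl on an amine nitrogen in a ring. Going by the values given here, no measured step touches the group on the amine nitrogen in the ring, so there is nothing to lean on beyond the low level of compound 3 and the modest spread between compound 3 and compound 1. Compound 4 is therefore expected to land near the low end, with a step of a number 12.2 percentage points higher from compound 3 to compound 4 (beyond the scatter) that could go either way and is unlikely to exceed the scatter by much. The estimate for compound 4 in this assay is 18%, within a range from 0% to 45%.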

Compound 4, a percentage reported as inhibition, in the whole organism at one dose (the size of the read-out at that dose, not a potency): 6.13%
For compound 4 the middle estimate is 11.9 percentage points above the measured one; the measured number falls inside the stated range.
By their numbers in this assay, from the lowest: compounds 3, 4 and 1 (each within the scatter of the next); then compound 2.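

Among the compounds shown here, the one measured step at this position, 2-methoxyphenyl in place of 3-chlorophenyl on an amine nitrogen in a ring, is a number 0.3 percentage points higher from compound 3 to compound 4 (within the scatter) in this assay. So this exchange of one substituted phenyl for another, with 4-chlorophenyl-bearing compound 3 as the starting point, does not register on this read-out, even though the entering group has a hydrogen-bond acceptor and the leaving group has none. Nothing available explains this outcome.

On these data alone, whether a different group on this nitrogen, such as a benzyl group or a chain ending in a carboxylic acid, would move the number beyond the scatter remains open. Compound 2 gives 63.5% but differs from compound 3 in more than one place, so which of its differences matters also stays unresolved.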